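The source may hold more compounds than are shown below. What is called first, only, known or untested is meant among the compounds shown, and "the series" means these compounds.

Measured so far in a functional assay on NCI-H460 cells (Homo sapiens) for antiproliferative activity, read by CCK-8 assay, with a stated time of 72 h, tested at 2 uM; on this read-out lower numbers stand for a weaker effect and higher numbers for a stronger effect at the one concentration tested:
- compound 1, `Nc1ccccc1NC(=O)c1ccc(COCNc2nc(Nc3ccccc3)c3ncn(C4CCCC4)c3n2)cc1`: 41.2%
- compound 2, `Nc1ccccc1NC(=O)c1ccc(COCNc2nc(Nc3cccc(Cl)c3)c3ncn(C4CCCC4)c3n2)cc1`: 36.1%

For the measured compounds named here, compound 2 stands beside compound 1 on this read-out, the only measured step being a number 5.1 percentage points lower from compound 1 to compound 2 (within the scatter), so the two numbers are not separated beyond the scatter.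

Compound 3, `Nc1ccccc1NC(=O)c1ccc(COCNc2nc(Nc3ccc(-c4ccccc4)cc3)c3ncn(C4CCCC4)c3n2)cc1`, is not yet measured. It differs from compound 2 by 4-phenylphenyl in place of 3-chlorophenyl on a nitrogen on an aromatic ring.

Going by the values given here, the single measured step touches the same aryl group on the same nitrogen, but exchanges a hydrogen for a chloro rather than adding a second ring, so it bears only loosely on the present change. Its size, a number 5.1 percentage points lower from compound 1 to compound 2 (within the scatter), gives no sign that this position moves the number beyond the scatter. The step to compound 3 is therefore expected to be small, with no clear direction, at about a number 1.9 percentage points higher from compound 2 to compound 3 (within the scatter).

Compound 3 is estimated at 38% in this assay, with a range from 20% to 56%.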

Compound 3, a percentage reported as inhibition, at one concentration (the size of the read-out at that concentration, not a potency): 33.5%
Compound 3: the middle estimate sits 4.5 percentage points above what was measured; the measured number falls inside the stated range.
By their numbers in this assay, from the lowest: compounds 3, 2 and 1 (each within the scatter of the next).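

At the aryl group on a nitrogen on an aromatic ring, a much larger carbon-only group now joins the series in this assay: 4-phenylphenyl in place of 3-chlorophenyl gives a number 2.6 percentage points lower from compound 2 to compound 3 (within the scatter), and adding a phenyl group to the plain aryl ring gives a number 7.7 percentage points lower from compound 1 to compound 3 (within the scatter). Even with 12 heavy atoms entering against 7 leaving and a second six-membered aromatic ring added, the number does not separate from those of the smaller aryl groups, so this position has not yet produced a step beyond the scatter. No supporting evidence bears on this result.

For the compounds shown here, all groups at this position so far carry only carbon or chlorine on the aryl ring. On these data alone, whether an amine or a carboxylic acid there would give a step beyond the scatter remains open.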